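The compounds below may be only part of what the source reports. "The series", "measured", "known", "first", "only" and "open" are said of these compounds alone.

For the measured compounds named here, in a functional assay on HL-60 cells (Homo sapiens) for cytotoxicity, read by MTT assay, with a stated time of 72 h (on this read-out lower numbers stand for stronger inhibition and higher numbers for weaker inhibition), compound 1 (`COC(=O)c1sc2cc(OC)ccc2c1Nc1cc(OC)c(OC)c(OC)c1`) gives 0.4 nM and holds the lowest of the three numbers measured so far. Compound 2 (`COC(=O)c1sc2cc(C)ccc2c1Nc1cc(OC)c(OC)c(OC)c1`) gives 20.5 nM and compound 3 (`CCOC(=O)c1sc2ncccc2c1Nc1cc(OC)c(OC)c(OC)c1`) gives 6100 nM on the same read-out. Compound 4 (`CCOC(=O)c1sc2cc(OC)ccc2c1Nc1cc(OC)c(OC)c(OC)c1`) has not yet been measured. It turns the methoxycarbonyl of compound 1 into ethoxycarbonyl, and methyl in place of hydrogen on a saturated chain carbon bound to an oxygen next to a carbonyl group is the whole difference.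

Going by the values given here, no measured step touches this group directly. Among the compounds with values here, the only single change on record, a 51-fold higher number from compound 1 to compound 2 (1.71 log units; beyond the scatter) for methyl in place of methoxy on an aromatic carbon, is a different edit, but it shows that one small change can move the number a long way in these compounds. Compound 3 also carries ethoxycarbonyl, with 6100 nM as its number, yet its core differs from that of compound 1, so this value cannot be pinned on the ester alone.

A step smaller than the large one above is therefore expected, toward a higher number and weaker inhibition, and the estimate is a 3.8-fold higher number from compound 1 to compound 4 (0.57 log units; beyond the scatter) in all. Compound 4 is expected to read 1.5 nM with an estimated range from 0.3 nM to 12 nM on this reasoning.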

Compound 4, half-maximal inhibitory concentration: 31.6 nM
Compound 4: the middle estimate sits 21-fold (1.32 log units) below what was measured; the measured number lies above the stated range.
By their numbers in this assay, from the lowest: compound 1; then compounds 2 and 4 (each within the scatter of the next); then compound 3.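

In this assay, this ester position proves highly sensitive: going from methoxycarbonyl to ethoxycarbonyl adds only a single methyl, yet it gives a 79-fold higher number from compound 1 to compound 4 (1.90 log units; beyond the scatter), a large loss of inhibition. The ester of compound 1 is therefore a second place where one small edit has a large effect, alongside the swap of methoxy for methyl on an aromatic carbon, which gives a 51-fold higher number from compound 1 to compound 2 (1.71 log units; beyond the scatter). No measurement at hand explains why this added methyl has so large an effect.

From the compounds shown here alone, it remains open how the number responds to other groups at this position, such as a carboxylic acid, an amide, or the longer chain of a propyl ester, and so whether the loss continues as the chain grows or depends on something else about the ester. Also open, going by these compounds, is whether the same change from methoxycarbonyl to ethoxycarbonyl gives a step of similar size on a different core, such as that of compound 3.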